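This account rests on a few compounds, and the source may have more. Where it says the series, first, only, none or still open, it means among the compounds named here.

Of the compounds shown here, two built on a shared core have been measured so far. Compound 1 `COc1ccc(/C=N\NC(=S)NC(C)(C)CCC[C@](C)(O)[C@@H]2CC=C(C)CC2)cc1` carries a methoxy group on its aromatic ring, and in a functional assay on OVCAR-3 cells (Homo sapiens) for cytotoxicity, read by sulforhodamine B assay (on this read-out higher numbers stand for lower toxicity in this test and lower numbers for higher toxicity in this test), compound 1 gives 46200 nM. Compound 2 `CC1=CC[C@@H]([C@@](C)(O)CCCC(C)(C)NC(=S)N/N=C\c2ccc(O)cc2)CC1` differs from it in that one place only, and in this assay compound 2 gives 54400 nM. The step of a 1.2-fold higher number from compound 1 to compound 2 (0.07 log units; within the scatter) shows how little that exchange mattered. On the two numbers in hand, compound 2 holds the highest number, with compound 1 nearest at a distance the test cannot tell apart.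

Compound 3 `CC1=CC[C@@H]([C@@](C)(O)CCCC(C)(C)NC(=S)N/N=C\c2ccc(N(C)C)cc2)CC1` has not yet been measured. It is made from compound 2 by one change: dimethylamino in place of hydroxy on an aromatic carbon. Within the data shown here, the only measured step that touches the same aromatic carbon is a 1.2-fold higher number from compound 1 to compound 2 (0.07 log units; within the scatter), which stayed within the scatter; no measured step exchanges hydroxy for dimethylamino, so that part rests on no direct evidence. The expectation is therefore a step of a 1.3-fold lower number from compound 2 to compound 3 (0.11 log units; within the scatter), with no movement beyond the scatter in either direction. Compound 3 is expected to give about 42000 nM, somewhere between 15000 nM and 110000 nM.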

Compound 3, concentration lethal to 50% of the cells: > 100000 nM
Compound 3 ended at the assay's limit; the forecaster's own chance of this, stated with the estimate: 15%; at least 2.3-fold (0.37 log units) between middle value and limit.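

Compound 3 stands at a limit of this assay, not at a number: the limit of > 100000 nM in this assay, at which 1 of the 3 values shown sits.

Its steps therefore give only floors, and the two floors read differently: dimethylamino in place of hydroxy gives an at least 1.8-fold higher number from compound 2 to compound 3 (0.26 log units; that floor lies within the scatter), while dimethylamino in place of methoxy gives an at least 2.1-fold higher number from compound 1 to compound 3 (0.33 log units; beyond the scatter). Among these compounds, that second step is the first at this aromatic carbon to pass beyond the scatter, and on this read-out its direction stands for lower toxicity in this test. The earlier exchange of methoxy and hydroxy could not show it, but the position para to a large group can respond to what stands on it, at least for this one pair of groups.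

The true value of compound 3 stays unknown, so the compounds shown cannot settle whether it differs from compound 2 beyond the scatter. Also open, going by these compounds, is whether this result is particular to dimethylamino or would also appear with a plain amine, a carboxylic acid or a longer chain on the same aromatic carbon.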